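A few compounds are considered here, and "the series" means these few. Any claim that something is new, unique, unknown or untested is made for them only; others in the source may bear on it.

Working notes on the series. In a functional assay on MDA-MB-231 cells (Homo sapiens) for antiproliferative activity, read by MTT assay, with a stated time of 72 h (a lower number here means a stronger inhibitor, a higher number a weaker inhibitor), compound 1 (`Cc1ccc(S(=O)(=O)Nc2cccc(-c3nc(-c4ccc(NC(=O)c5cccnc5)cc4Cl)no3)c2)cc1`) gives > 10000 nM as a limit of the assay and not a number. Compound 1 stands at the limit of > 10000 nM in this assay, at which 1 of the 2 values shown sits, and has no exact reading. For the measured compounds named here, compound 2 (`CC(=O)Nc1ccc(S(=O)(=O)Nc2cccc(-c3nc(-c4ccc(NC(=O)c5cccnc5)c(Cl)c4)no3)c2)cc1`) reads 4500 nM as the only true number so far.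

Compound 3 (`CNC(=O)Nc1ccc(S(=O)(=O)Nc2cccc(-c3nc(-c4ccc(NC(=O)c5cccnc5)cc4Cl)no3)c2)cc1`) is still unmeasured and keeps the core of compound 1 apart from one change ((methylcarbamoyl)amino in place of methyl on an aromatic carbon) that puts (methylcarbamoyl)amino in place of methyl on an aromatic carbon, para to a large group. Going by the values given here, no measured step isolates this change in this assay, so the expectation rests on the few values available. With compound 2 at 4500 nM as a reading inside the range of the assay, a number looks reachable for compound 3. A second limit remains possible for compound 3. The step expected is an at least 1.6-fold lower number from compound 1 to compound 3 (0.22 log units; that floor lies within the scatter) and is estimated as modest, toward stronger inhibition. For compound 3 the estimated value is 6000 nM with an expected range (2000 nM to 15000 nM) around it.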

Compound 3, half-maximal inhibitory concentration: 1300 nM
Compound 3: the middle estimate sits 4.6-fold (0.66 log units) above what was measured; the measured number lies below the stated range.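

In this assay, for the compounds shown here, the first step that can be read at this position, on an aromatic carbon para to a large group, is an at least 7.6-fold lower number from compound 1 to compound 3 (0.88 log units; beyond the scatter), with (methylcarbamoyl)amino in place of methyl. The position is therefore not indifferent to what it carries: with the rest of the core of compound 1 unchanged, this single change gives a reading inside the range of the assay. Compound 1 stands at a limit of the assay, > 10000 nM, and not a number, so the step is only a floor and its full size stays unfixed: the limit of > 10000 nM in this assay, at which 1 of the 3 values shown sits.

As far as these compounds go, whether the whole (methylcarbamoyl)amino group is needed for a step of this size remains open, since a plain amine, a carboxylic acid or a longer chain at the same position on the core of compound 1 could separate the contribution of its parts. Compound 2 differs from compound 3 in more than one place, so it cannot show how this group compares with the substituent that compound 2 carries at the same position.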